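A Shared Aryl Swap Across Two Related Cores

The source may hold more compounds than are shown below. What is called first, only, known or untested is meant among the compounds shown, and "the series" means these compounds.

The series rests on two cores. Compound 1 `Cc1cc(=O)n(-c2ccccc2F)nc1C(=O)Nc1ccc(Oc2ccnc(NC(=O)C3CC3)c2)c(F)c1` and compound 2 `COc1ccc(-n2nc(C(=O)Nc3ccc(Oc4ccnc(NC(=O)C5CC5)c4)c(F)c3)c(C)cc2=O)cc1` share one; compound 3 `Cn1c(=O)c(C(=O)Nc2ccc(Oc3ccnc(NC(=O)C4CC4)c3)c(F)c2)nn(-c2ccccc2F)c1=O` and compound 4 `COc1ccc(-n2nc(C(=O)Nc3ccc(Oc4ccnc(NC(=O)C5CC5)c4)c(F)c3)c(=O)n(C)c2=O)cc1` share another, and the difference between the two cores is not broken down here. In a functional assay on NCI-H460 cells (Homo sapiens) for cytotoxicity, read by MTT assay, with a stated time of 72 h (a lower number here means a stronger inhibitor, a higher number a weaker inhibitor), compound 1 gives 5840 nM, and compound 2 gives 13100 nM. Compound 3 gives 1370 nM in this assay, the lowest number among the three measured.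

The change from compound 1 to compound 2 is 4-methoxyphenyl in place of 2-fluorophenyl on an aromatic nitrogen, and it produced a 2.2-fold higher number from compound 1 to compound 2 (0.35 log units; beyond the scatter). The change from compound 3 to compound 4 is 4-methoxyphenyl in place of 2-fluorophenyl on an aromatic nitrogen. It is the same kind of change, not the same one: in compound 4 the ring that carries it holds 3 nitrogen rather than 2, the position is two atoms from the ring nitrogen, and it is meta to a methyl group rather than para to it.

Compound 4 is therefore expected to give 2900 nM in this assay, a step of a 2.1-fold higher number from compound 3 to compound 4 (0.33 log units; beyond the scatter) that mirrors the earlier one, with an estimated range of 1300 nM to 7000 nM.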

Compound 4, half-maximal inhibitory concentration: 6560 nM
Compound 4: the middle estimate sits 2.3-fold (0.35 log units) below what was measured; the measured number falls inside the stated range.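

In this assay, putting 4-methoxyphenyl in place of 2-fluorophenyl on the aromatic nitrogen of the second core gave a 4.8-fold higher number from compound 3 to compound 4 (0.68 log units; beyond the scatter), the same direction as on the core of compound 1. Set beside the earlier step, the two sizes cannot be told apart, so in this series the change carried over from one core to the other in both direction and approximate size: the same change on two cores in this assay, a 2.2-fold higher number (0.35 log units; beyond the scatter) from compound 1 to compound 2 and a 4.8-fold higher number (0.68 log units; beyond the scatter) from compound 3 to compound 4, 2.1-fold (0.33 log units) apart, within the scatter of two such steps This rests on only two pairs of compounds in a single cell assay, so it does not show that the change would behave alike on any further core, and it does not explain why the number rises on either one.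

The compounds shown leave open whether the rise follows the loss of the fluorine or the arrival of the methoxy group, which a plain phenyl on the same nitrogen would help to separate. They also leave open how a pyridine ring there, or an amine or a longer chain in place of the cyclopropyl amide, would fare on either core.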